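The compounds below may be only part of what the source reports. "The series", "measured", "known", "first", "only" and "open" are said of these compounds alone.

Compound 1 `O=C1c2c[n+]([O-])c3ccccc3c2C(=O)c2c1c1ccccc1n2CCN1CCCC1`: in a functional assay on MCF7 cells (Homo sapiens) for cytotoxicity, read by MTT assay, with a stated time of 72 h (a lower number here means a stronger inhibitor, a higher number a weaker inhibitor), compound 1 gives 320 nM.
Compound 2 `O=C1c2c[n+]([O-])c3ccccc3c2C(=O)c2c1c1ccccc1n2Cc1cn(C[C@@H](O)CO)nn1`: in this assay compound 2 gives 600 nM.

Going by the values given here, of the two numbers measured so far, compound 2 has the highest; its nearest neighbour is compound 1, and the step of a 1.9-fold higher number from compound 1 to compound 2 (0.27 log units; within the scatter) lies within the scatter, so the two values cannot be ordered. That step exchanged (pyrrolidin-1-yl)methyl for 1-(2,3-dihydroxypropyl)-1H-1,2,3-triazol-4-yl on a saturated chain carbon bound to an aromatic nitrogen.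

Compound 3 `O=C1c2c[n+]([O-])c3ccccc3c2C(=O)c2c1c1ccccc1n2CCCN1CCC(O)CC1` differs from compound 2 at the same place: 2-(4-hydroxypiperidin-1-yl)ethyl in place of 1-(2,3-dihydroxypropyl)-1H-1,2,3-triazol-4-yl on a saturated chain carbon bound to an aromatic nitrogen. Among the compounds with values here, the only step that bears on this change is the one from compound 1 to compound 2, which altered this same substituent and stayed within the scatter. Nothing measured speaks for a large movement in either direction. Compound 3 is therefore expected to stay close to compound 2, with an estimated step of a 1.4-fold lower number from compound 2 to compound 3 (0.15 log units; within the scatter), a number in this assay of about 420 nM being expected, within a range from 150 nM to 1200 nM.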

Compound 3, half-maximal inhibitory concentration: 190 nM
Compound 3: the middle estimate sits 2.2-fold (0.34 log units) above what was measured; low and high end bracket the measured number.
By their numbers in this assay, from the lowest: compounds 3, 1 and 2 (each within the scatter of the next, the first and the last beyond it).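

In this assay this position turns out to be able to move the number beyond the scatter, which the earlier pair had not shown: putting 2-(4-hydroxypiperidin-1-yl)ethyl in place of 1-(2,3-dihydroxypropyl)-1H-1,2,3-triazol-4-yl gives a modest but readable change (a 3.2-fold lower number from compound 2 to compound 3 (0.50 log units; beyond the scatter)). The exchange of pyrrolidin-1-yl for (4-hydroxypiperidin-1-yl)methyl does not separate the two compounds with a non-aromatic ring on the chain (a 1.7-fold lower number from compound 1 to compound 3 (0.23 log units; within the scatter)), and compound 2 stands apart only from compound 3, not from compound 1, so the triazole compound cannot be set apart from both. The data at hand offer no measurement that would explain the step from compound 2 to compound 3.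

The change from compound 2 to compound 3 alters the ring, the chain and the hydroxyl groups together, so the compounds shown do not tell which of these carries the lower number. On these data alone, whether a morpholine, a dimethylamino group or a carboxylic acid at the end of the same chain would stay near compound 3 also remains open.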